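The compounds below may be only part of what the source reports. "The series", "measured", "known", "first", "only" and "open" are said of these compounds alone.

Three related compounds have been tested in a functional assay on MCF7 cells (Homo sapiens) for antiproliferative activity, with a stated time of 5 days; on this read-out higher numbers stand for weaker inhibition and lower numbers for stronger inhibition. Compound 1 `COc1ccc(-c2[nH]c3ccc(OC)cc3c2C=C(C#N)C#N)cc1` gives 340 nM in this assay. Compound 2 `COc1ccc(-c2[nH]c3cc(OC)ccc3c2C=C(C#N)C#N)cc1` shares its atoms with compound 1 but joins them differently; how the two cores differ is not broken down here. In this assay compound 2 gives 300 nM. Compound 3 `COc1ccc(-c2[nH]c3ccc(F)cc3c2C=C(C#N)C#N)cc1` is made from compound 1 by a single change: fluoro in place of methoxy on an aromatic carbon. In this assay compound 3 gives 310 nM. Between these two compounds the change produced a 1.1-fold lower number from compound 1 to compound 3 (0.04 log units; within the scatter), so the read-out did not move in any meaningful way.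

Compound 4 `COc1ccc(-c2[nH]c3cc(F)ccc3c2C=C(C#N)C#N)cc1` has not yet been measured. It is made from compound 2 by the same change: fluoro in place of methoxy on an aromatic carbon. Among the compounds with values here, the place description is the same word for word as the one between compound 1 and compound 3, so this is the same change, now carried out on the core of compound 2 instead of the core of compound 1. The change occurs twice among the compounds shown, and the one measured instance of it stayed within the usual scatter.

Because the earlier instance gave a 1.1-fold lower number from compound 1 to compound 3 (0.04 log units; within the scatter), the expected step from compound 2 to compound 4 is a 1.1-fold lower number from compound 2 to compound 4 (0.03 log units; within the scatter), which is only the estimate of a barely moved number. Because compound 2 gives 300 nM, compound 4 is expected to give about 280 nM in this assay, with an estimated range from 150 nM to 550 nM.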

Compound 4, half-maximal inhibitory concentration: 220 nM
Estimate against measurement, compound 4: 1.3-fold (0.10 log units) above; measured number inside the range.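

In this assay, putting fluoro in place of methoxy on the core of compound 2 gives a 1.4-fold lower number from compound 2 to compound 4 (0.13 log units; within the scatter), so the read-out again stays within what repeated measurements would be expected to show. Set beside the earlier case, the two cores answer this change in the same way: the same change on two cores in this assay, a 1.1-fold lower number (0.04 log units; within the scatter) from compound 1 to compound 3 and a 1.4-fold lower number (0.13 log units; within the scatter) from compound 2 to compound 4, 1.2-fold (0.09 log units) apart, within the scatter of two such steps. Within the data shown here, in these compounds the swap therefore carries from one core to the other without a measurable difference, but this rests on only two pairs in a single cell assay, and since neither step leaves the scatter, it does not show that fluoro is better or worse than methoxy, or that a change with a clear effect would carry across in the same way.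

The compounds shown hold only methoxy and fluoro at this place on the ring, and how the read-out would respond to an amine, a carboxylic acid or a longer chain there remains open. Also open is whether the two nitrile groups matter for the read-out, as every compound shown carries them unchanged.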